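Swapping the indanyl amine for an aminopyridine on the piperidine

This account rests on a few compounds, and the source may have more. Where it says the series, first, only, none or still open, it means among the compounds named here.

Measured compounds:
compound 1 `O[C@H]1Cc2ccccc2C1NC1CCN(CCCc2c[nH]c3ccc(-n4cnnc4)cc23)CC1`: 37 nM
compound 2 `CC(=O)Nc1ccc([C@H](C)NCC2CCN(CCCc3c[nH]c4ccc(-n5cnnc5)cc34)CC2)cc1`: 0.6 nM
compound 3 `C[C@@H](NC1CCN(CCCc2c[nH]c3ccc(-n4cnnc4)cc23)CC1)c1ccccc1`: 0.4 nM

In an assay on CHO cells for displacement of a labelled ligand from 5-hydroxytryptamine receptor 1D (Homo sapiens) (on this read-out higher numbers stand for weaker inhibition and lower numbers for stronger inhibition), compound 1 gives the highest of the three numbers; compound 2 and compound 3 both sit far lower, and each of those gaps is beyond the scatter. Among the measured compounds shown here, the one step that can be followed in a single place is a 93-fold lower number from compound 1 to compound 3 (1.97 log units; beyond the scatter), where 1-phenylethyl replaces 2-hydroxy-2,3-dihydro-1H-inden-1-yl on an amine nitrogen. That is a large gain.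

Compound 4 `c1ccc(NCC2CCN(CCCc3c[nH]c4ccc(-n5cnnc5)cc34)CC2)nc1` has not been measured. It differs from compound 1 in one place: ((pyridin-2-yl)amino)methyl in place of (2-hydroxy-2,3-dihydro-1H-inden-1-yl)amino on a saturated ring carbon. Like compound 3, compound 4 gives up the 2-hydroxy-2,3-dihydro-1H-inden-1-yl group, and the group that enters carries an aromatic ring, as in compound 2 and compound 3. The step from compound 1 to compound 3 therefore bears on it, but the entering group is not the same, so a smaller gain is expected. For compound 4 the expected step is a 6.2-fold lower number from compound 1 to compound 4 (0.79 log units; beyond the scatter), and the estimated value in this assay is 6 nM, with a range from 1.5 nM to 25 nM.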

Compound 4, half-maximal inhibitory concentration: 1.7 nM
Compound 4: the middle estimate sits 3.5-fold (0.55 log units) above what was measured; the range from low to high includes it.
By their numbers in this assay, from the lowest: compounds 3 and 2 (each within the scatter of the next); then compound 4; then compound 1.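

In this assay, the large gain at this position does not rest on the 1-phenylethyl group alone: ((pyridin-2-yl)amino)methyl on the same saturated ring carbon also gives a 22-fold lower number from compound 1 to compound 4 (1.34 log units; beyond the scatter). The new group does not go quite as far as the two best compounds, with a 4.3-fold higher number from compound 3 to compound 4 (0.63 log units; beyond the scatter) and a 2.8-fold higher number from compound 2 to compound 4 (0.45 log units; beyond the scatter), both modest steps. A pyridin-2-yl group directly on the amine nitrogen therefore keeps most of the gain, so more than one aromatic group can replace the 2-hydroxy-2,3-dihydro-1H-inden-1-yl group here.

No measurement shown explains why the numbers move. As far as these compounds go, whether the nitrogen of the pyridine ring matters stays open, and a plain phenyl in place of the pyridin-2-yl group would test that.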